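Oxolane ring against methyl on the benzylic carbon

The source may report more compounds than this note shows. Statements on the series, on what has been measured and on what is new or still open speak of the compounds shown alone.

Measured compounds:
compound 1 `Cc1cc(C)c(CN2CCc3c(Cl)cc([C@H](CO)[C@H]4CCOC4)c(Cl)c3C2=O)c(=O)[nH]1`, 10 nM
compound 2 `Cc1cc(C)c(CN2CCc3c(Cl)cc([C@H](CO)[C@@H]4CCCO4)c(Cl)c3C2=O)c(=O)[nH]1`, 41 nM
compound 3 `Cc1cc(C)c(CN2CCc3c(Cl)cc([C@H](C)CO)c(Cl)c3C2=O)c(=O)[nH]1`, 129 nM

In an assay on cells for inhibition of histone-lysine N-methyltransferase EZH2 (Homo sapiens), read by ELISA, with a stated time of 72 h (on this read-out higher numbers stand for weaker inhibition and lower numbers for stronger inhibition), compound 3 gives the highest number of the three: compound 2 sits nearer, compound 1 furthest, as the steps of a 3.1-fold higher number from compound 2 to compound 3 (0.50 log units; beyond the scatter) and a 13-fold higher number from compound 1 to compound 3 (1.11 log units; beyond the scatter) show. Compound 4 `Cc1cc(C)c(CN2CCc3c(Cl)cc([C@@H](CO)[C@H]4CCCO4)c(Cl)c3C2=O)c(=O)[nH]1` is obtained from compound 3 by the change (oxolan-2-yl in place of methyl on a saturated chain carbon bound to an aromatic carbon and a saturated chain carbon). The step that bears on this is a 3.1-fold higher number from compound 2 to compound 3 (0.50 log units; beyond the scatter), run in reverse: compound 2 carries the same groups as compound 4, but its stereocentres are set otherwise, so the gain seen there need not carry over in full. A reduction in the number is expected, but a smaller one than the reverse of that modest step; the estimate for compound 4 in this assay is 80 nM, with a range from 25 nM to 300 nM, which means the expected step of a 1.6-fold lower number from compound 3 to compound 4 (0.21 log units; within the scatter).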

Compound 4, half-maximal inhibitory concentration: 1020 nM
Compound 4: middle estimate off by 13-fold (1.11 log units), on the low side; measured number outside the range, above it.
By their numbers in this assay, from the lowest: compound 1; then compound 2; then compound 3; then compound 4.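

In this assay, oxolan-2-yl in place of methyl on this saturated chain carbon does not lower the number in every form: the change can raise it, with a 7.9-fold higher number from compound 3 to compound 4 (0.90 log units; beyond the scatter), although compound 2, which carries the same groups, gives a lower number than compound 3. The direction of this change therefore depends on configuration, as a 25-fold higher number from compound 2 to compound 4 (1.40 log units; beyond the scatter) shows, and the comparison isolates that factor: the fact that compounds 2 and 4 differ only in the configuration as drawn. The span at this position also widens to a 100-fold higher number from compound 1 to compound 4 (2.01 log units; beyond the scatter), between two groups with the same atom counts.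

From the compounds shown here alone, it remains open what the two other pairings of these stereocentres would give with oxolan-2-yl, and how far inverting compound 1 would change its number. Going by these compounds, how an amine or a longer chain in place of the oxolane ring would behave on this carbon is also open.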